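The source may report more compounds than this note shows. Statements on the series, on what has been measured and on what is new or still open speak of the compounds shown alone.

Working notes on the series. The shared core appears in compound 1 `CS(=O)(=O)c1ccc(C(=O)N2CCC(C(=O)N3CCN(c4ccc(F)cc4)CC3)CC2)cc1[N+](=O)[O-]`. In an assay on isolated protein for inhibition of thyroid hormone receptor beta (Homo sapiens), read by fluorescence polarization (a lower number here means a stronger inhibitor, a higher number a weaker inhibitor), compound 1 returns > 60000 nM, which is a limit of the assay and not a number. Compound 2 `Cc1ccc(N2CCN(C(=O)C3CCN(C(=O)c4ccc(S(C)(=O)=O)c([N+](=O)[O-])c4)CC3)CC2)cc1` carries methyl in place of fluoro on an aromatic carbon. In this assay compound 2 returns > 60000 nM, again a limit. The step that the two limits leave unreadable from compound 1 to compound 2 is therefore unreadable in size. Compound 3 `CS(=O)(=O)c1ccc(C(=O)NCC(=O)N2CCCCC2)cc1[N+](=O)[O-]` keeps the same acyl half of the core with a shorter link to the terminal amide. In this assay compound 3 returns > 60000 nM, a limit of the assay. Where compound 3 stands is thus fixed only by the limit of > 60000 nM in this assay, at which 3 of the 3 values shown sit; no measured value in the set lies away from that limit.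

Compound 4 `CC(C)N(C(=O)CNC(=O)c1ccc(S(C)(=O)=O)c([N+](=O)[O-])c1)C(C)C` differs from compound 3 by diisopropylamino in place of piperidin-1-yl on a carbonyl carbon. For the measured compounds named here, no measured step bears directly on this change, and the one measured step, a step that the two limits leave unreadable from compound 1 to compound 2, gives no readable size at all. Compound 4 is expected to remain at the limit because the limit of > 60000 nM in this assay, at which 3 of the 3 values shown sit, leaves no measured value elsewhere. For compound 4 the estimate in this assay is 100000 nM, with a range of 30000 nM to 300000 nM, most likely reported as a limit. The expected step that the limit leaves unreadable from compound 3 to compound 4 is accordingly none that could be read.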

Compound 4, half-maximal inhibitory concentration: > 60000 nM
Compound 4: only a limit was reported (the forecaster's own chance of this, stated with the estimate: 85%); the middle value lies beyond the limit too.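

In this assay compound 4 gives > 60000 nM, a limit of the assay and not a number. The step from compound 3 to compound 4 therefore cannot be read in size. The compounds shown leave open which change to the shared core would give a measured value at all, because every result rests on one limit: the limit of > 60000 nM in this assay, at which 4 of the 4 values shown sit.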